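The compounds below may be only part of what the source reports. "The series", "measured", "known", "first", "only" and "open" are said of these compounds alone.

Measured compounds in a functional assay on MCF7 cells (Homo sapiens) for inhibition, read by sulforhodamine B assay, with a stated time of 48 h; on this read-out higher numbers stand for weaker inhibition of growth and lower numbers for stronger inhibition of growth:
compound 1 `COc1ccc(/C=C/C2CC=CC(=O)O2)cc1OC`: 7.8 uM
compound 2 `COc1cc(OC)c(OC)cc1/C=C/C1CC=CC(=O)O1`: 3.8 uM
compound 3 `COc1ccc(/C=C/C2CC=CC(=O)N2)cc1`: > 1090 uM

The value given for compound 3 in this assay is a limit of the method, not a number (the limit of > 1090 uM in this assay, at which 1 of the 3 values shown sits). How the core of compound 3 differs from the core of compound 1 is not broken down here.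

Between compound 1 and compound 2 the change is methoxy in place of hydrogen on an aromatic carbon, and it gives a 2.1-fold lower number from compound 1 to compound 2 (0.31 log units; beyond the scatter). Compound 4 `COc1ccc(/C=C/C2CC=CC(=O)N2)c(OC)c1`, not yet measured, is reached from compound 3 by methoxy in place of hydrogen on an aromatic carbon. Within the data shown here, this is the same kind of change, but the place is not the same word for word: in compound 2 the entering methoxy is also para to a methoxy group, which has no counterpart in compound 4.

For compound 4 in this assay a step of about an at least 1.3-fold lower number from compound 3 to compound 4 (0.13 log units; that floor lies within the scatter) is expected, resting on the modest size seen for compound 2 against compound 1 and on compound 3 sitting at a limit. Compound 4 is estimated at 800 uM, between 200 uM and 3000 uM, and a limit is likely again.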

Compound 4, concentration for growth inhibition (reported as GI): > 964 uM
Compound 4 was reported as a limit; the forecaster's own chance of this, stated with the estimate: 75%; middle value at least 1.2-fold (0.08 log units) from the limit.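

In this assay, compound 3 and compound 4 are both reported only as limits, and the step between them cannot be read. On these data alone, whether methoxy in place of hydrogen on an aromatic carbon changes growth inhibition on the core of compound 3 stays open.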